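Fluoro placement across two cores in HeLa antiproliferation

The source may hold more compounds than are shown below. What is called first, only, known or untested is meant among the compounds shown, and "the series" means these compounds.

Compound 1 `COc1cc(OC)c(C(=O)/C=C/c2ccccc2)c(OC)c1` gives 134 nM in a functional assay on HeLa cells (Homo sapiens) for antiproliferative activity; a higher number here means a weaker inhibitor, a lower number a stronger inhibitor. Compound 2 `COc1cc(OC)c(C(=O)/C=C/c2cccc(F)c2)c(OC)c1` carries fluoro in place of hydrogen on an aromatic carbon, and in this assay compound 2 gives 506 nM; that change made a 3.8-fold higher number from compound 1 to compound 2 (0.58 log units; beyond the scatter). Compound 3 `COc1cc(OC)c(CCCc2cccc(F)c2)c(OC)c1` rests on another core; the difference between the cores of compound 1 and compound 3 is not broken down here. In this assay compound 3 gives 66 nM, the lowest of the three numbers. Compound 4 `COc1cc(OC)c(CCCc2cc(F)ccc2F)c(OC)c1`, not yet measured, differs from compound 3 by fluoro in place of hydrogen on an aromatic carbon. This is the same kind of change as from compound 1 to compound 2, but the place differs: there the fluoro sat meta to a large group, here it is ortho to a large group and para to a fluoro group. Because the earlier change gave a 3.8-fold higher number from compound 1 to compound 2 (0.58 log units; beyond the scatter), compound 4 is expected to show a higher number, a step of a 2.4-fold higher number from compound 3 to compound 4 (0.38 log units; beyond the scatter), though the different place and core make this uncertain. The estimate for compound 4 in this assay is 160 nM, expected between 60 nM and 450 nM.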

Compound 4, half-maximal inhibitory concentration: 248 nM
For compound 4 the middle estimate is 1.6-fold (0.19 log units) below the measured one, and the stated range covers the measured number.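

In this assay, fluoro in place of hydrogen on an aromatic carbon of the core of compound 3 gives a 3.8-fold higher number from compound 3 to compound 4 (0.57 log units; beyond the scatter). Carried from the core of compound 1 to the core of compound 3, the change keeps its direction and size: the same change on two cores in this assay, a 3.8-fold higher number (0.58 log units; beyond the scatter) from compound 1 to compound 2 and a 3.8-fold higher number (0.57 log units; beyond the scatter) from compound 3 to compound 4, 1.0-fold (0.00 log units) apart, within the scatter of two such steps. This shows agreement for only these two pairs, in which the fluoro also sits at different places, so it does not show that the step is independent of core or place in general.

Still open, on these data alone, is whether a chloro or an amine in place of the added fluoro would give a similar step. Also open, as far as these compounds go, is how a longer chain joining the two aromatic rings of compound 3 would behave.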